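Chain variation on the shared core, cytotoxicity in HeLa cells

The source may hold more compounds than are shown below. What is called first, only, known or untested is meant among the compounds shown, and "the series" means these compounds.

Compound 1 `COc1cc(C(c2ccc(O)c(OC)c2)[C@@H](C)[C@@H](C)CF)ccc1O` and compound 2 `COc1cc(C(c2ccc(O)c(OC)c2)[C@H](C)[C@H](C)CF)ccc1O` share the core and differ only in configuration as drawn. For the measured compounds named here, in a functional assay on HeLa cells (Homo sapiens) for cytotoxicity, read by WST assay, with a stated time of 48 h (a higher number here means a weaker inhibitor, a lower number a stronger inhibitor), compound 1 gives 42000 nM, the lowest of the two numbers so far, and compound 2 gives 75000 nM. Going by the values given here, the only measured step is a 1.8-fold higher number from compound 1 to compound 2 (0.25 log units; within the scatter); it concerns the configuration alone the fact that compounds 1 and 2 differ only in the configuration as drawn and says nothing about a change of the chain itself.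

Compound 3 `COc1cc(C(c2ccc(O)c(OC)c2)[C@H](CO)C(C)C)ccc1O` is not yet measured. Relative to compound 1 it carries 1-(hydroxymethyl)-2-methylpropyl in place of 2-(fluoromethyl)-1-methylpropyl on a saturated chain carbon bound to two aromatic carbons. Among the compounds with values here, no measured step covers an exchange of this kind, so the only anchor is the number of compound 1 and the spread between mirror images, which is within the scatter. The estimate for compound 3 is therefore set close to compound 1, with a broad range in both directions. The expected step from compound 1 to compound 3 is a 1.2-fold higher number from compound 1 to compound 3 (0.08 log units; within the scatter), a step of no clear direction. For compound 3 in this assay the expected value is 50000 nM, within 15000 nM to 200000 nM.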

Compound 3, half-maximal inhibitory concentration: > 100000 nM
Compound 3: no number, only a limit; the forecaster's own chance of this, stated with the estimate: 20%; at least 2.0-fold (0.30 log units) between middle value and limit.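

For compound 3, this assay gives only a limit, not a number: the limit of > 100000 nM in this assay, at which 1 of the 3 values shown sits.

Exchanging 2-(fluoromethyl)-1-methylpropyl for 1-(hydroxymethyl)-2-methylpropyl on a saturated chain carbon bound to two aromatic carbons gives an at least 2.3-fold higher number from compound 1 to compound 3 (0.37 log units; beyond the scatter) and an at least 1.3-fold higher number from compound 2 to compound 3 (0.12 log units; that floor lies within the scatter), so only the first of these floors clears the scatter, and both remain floors rather than measured sizes. Unlike the earlier pair, this result shows that a change of the chain itself can move the number beyond the scatter, which the earlier pair could not show: the fact that compounds 1 and 2 differ only in the configuration as drawn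

The compounds shown do not separate the exchange of fluorine for oxygen from the different branching of the two chains, and the actual number of compound 3 remains unknown. On these data alone, how a chain carrying an amine or a carboxylic acid, or a longer chain, would read in this assay also stays open.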